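Swapping One Halogenated Phenyl for Another on a Triazole

The source may hold more compounds than are shown below. What is called first, only, known or untested is meant among the compounds shown, and "the series" means these compounds.

Of the compounds shown here, three have been tested in an ADME assay on Huh-7 cells (Homo sapiens) for cytotoxicity, read by MTT assay, with a stated time of 72 h; on this read-out lower numbers stand for higher toxicity in this test and higher numbers for lower toxicity in this test. Compound 1 `COc1cc(O)c(C(=O)/C=C/c2ccc(OCc3cn(-c4ccc(Cl)cc4)nn3)c(OCc3cn(-c4ccc(Cl)cc4)nn3)c2)c(OC)c1` sits at the limit of > 100 ug/mL. Compound 3 `COc1cc(OC)c2c(=O)cc(-c3ccc(OCc4cn(-c5ccc(Cl)cc5)nn4)c(OC)c3)oc2c1` likewise reaches only the limit of > 100 ug/mL. Compound 2 `COc1cc(O)c(C(=O)/C=C/c2ccc(OC)c(OCc3cn(-c4ccc(F)c(Cl)c4)nn3)c2)c(OC)c1` also gives a limit, > 100 ug/mL, so no numeric value exists for it, and the limit of > 100 ug/mL in this assay, at which 3 of the 3 values shown sit, shows all three results resting on that same limit.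

Compound 4 `COc1cc(O)c(C(=O)/C=C/c2ccc(OC)c(OCc3cn(-c4ccc(Cl)cc4)nn3)c2)c(OC)c1` differs from compound 2 in one place: 4-chlorophenyl in place of 3-chloro-4-fluorophenyl on an aromatic nitrogen. Nothing measured here connects two compounds by a single change, so the step is judged only from the shared limit. The step from compound 2 to compound 4 in this assay is expected to be a step that the limit leaves unreadable from compound 2 to compound 4, within the scatter. Compound 4 is therefore expected to show 150 ug/mL, between 80 ug/mL and 300 ug/mL.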

Compound 4, half-maximal cytotoxic concentration: > 100 ug/mL
Compound 4: only a limit was reported; the forecaster's own chance of this, stated with the estimate: 85%; the middle value lies beyond the limit too.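

The limit > 100 ug/mL is all that compound 4 gives. Among the compounds shown here, no step from compound 2 or compound 1 to compound 4 can be read: the limit of > 100 ug/mL in this assay, at which 4 of the 4 values shown sit.

Where any of these four compounds would truly reach its half-maximal cytotoxic concentration in this assay stays open.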